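Swapping methoxycarbonyl for fluoro: a step with little precedent

The source may report more compounds than this note shows. Statements on the series, on what has been measured and on what is new or still open speak of the compounds shown alone.

Compound 1 `COc1ccc(CNc2cc(OC)c(OC)c(OC)c2)cc1Cl`: 41700 nM
Compound 2 `COC(=O)c1cc(CNc2cc(OC)c(OC)c(OC)c2)ccc1OC`: 38100 nM

Both compounds were tested in a functional assay on HCT-116 cells (Homo sapiens) for inhibition, read by MTT assay, with a stated time of 48 h; a higher number here means a weaker inhibitor, a lower number a stronger inhibitor. Compound 2 holds the lower of the two numbers, but its value lies within the usual scatter of the value for compound 1, so neither compound counts as the stronger inhibitor.

The next compound is compound 3 `COc1ccc(CNc2cc(OC)c(OC)c(OC)c2)cc1F`. It differs from compound 2 by fluoro in place of methoxycarbonyl on an aromatic carbon, ortho to a methoxy group: fluoro in place of methoxycarbonyl on an aromatic carbon.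

Among the measured compounds shown here, only one measured step bears on this change. It is a 1.1-fold lower number from compound 1 to compound 2 (0.04 log units; within the scatter), where methoxycarbonyl took the place of chloro on an aromatic carbon. That step stayed within the scatter, but it is a single comparison and involves chloro, not fluoro, so it offers only modest guidance. On that basis, no shift beyond the scatter is expected in this assay, in either direction. The expected step is a 1.0-fold higher number from compound 2 to compound 3 (0.02 log units; within the scatter). For compound 3 the estimated value is 40000 nM, with an expected range from 20000 nM to 80000 nM.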

Compound 3, half-maximal inhibitory concentration: 32200 nM
Compound 3: the middle estimate sits 1.2-fold (0.09 log units) above what was measured; low and high end bracket the measured number.
By their numbers in this assay, from the lowest: compounds 3, 2 and 1 (each within the scatter of the next).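

At this position, ortho to a methoxy group, three different groups have now been compared: chloro, methoxycarbonyl and fluoro. In this assay, replacing methoxycarbonyl with fluoro removes a group of 4 heavy atoms and 2 hydrogen-bond acceptors and puts in a single heavy atom with no hydrogen-bond acceptors, yet the step stays within the scatter (a 1.2-fold lower number from compound 2 to compound 3 (0.07 log units; within the scatter)), and replacing chloro with fluoro also stays within the scatter (a 1.3-fold lower number from compound 1 to compound 3 (0.11 log units; within the scatter)). Among these three compounds, then, even this large difference in heavy-atom count and hydrogen-bond acceptors comes with no change beyond the scatter, although three compounds cannot show that this would hold for other groups, and no measurement shown here says why the three groups read alike.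

The compounds shown leave open whether a different kind of group at this position, such as an amine, a carboxylic acid or a longer chain, would shift the number beyond the scatter. They also leave open whether a change elsewhere on the shared core would matter more than any change made here.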